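The compounds below may be only part of what the source reports. "The series", "measured", "known", "first", "only" and "open" are said of these compounds alone.

Working notes on the series.

Three compounds share one core and differ only in the group on the nitrogen on the aromatic ring. Compound 1 `N#Cc1cnc(NCc2cnccc2C(F)(F)F)cc1N[C@H]1CC[C@@H](O)CC1` gives 100 nM in an assay on isolated protein for inhibition of protein kinase C theta type (Homo sapiens), read by TR-FRET, with a stated time of 2 h; on this read-out higher numbers stand for weaker inhibition and lower numbers for stronger inhibition. Compound 2 `N#Cc1cnc(NCc2cnccc2C(F)(F)F)cc1NC[C@H]1CC[C@H](O)CC1` gives 50 nM; the step of a 2.0-fold lower number from compound 1 to compound 2 (0.30 log units; within the scatter) is within the scatter. Compound 3 `N#Cc1cnc(NCc2cnccc2C(F)(F)F)cc1N[C@H]1CC[C@@H](C(N)=O)CC1` gives 7 nM and stands lowest of the three numbers, with a 14-fold lower number from compound 1 to compound 3 (1.15 log units; beyond the scatter) and a 7.1-fold lower number from compound 2 to compound 3 (0.85 log units; beyond the scatter) both beyond the scatter.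

Compound 4 `N#Cc1cnc(NCc2cnccc2C(F)(F)F)cc1N[C@H]1CC[C@@H](c2nc[nH]n2)CC1` is not yet measured. It differs from compound 3 in one place: 1H-1,2,4-triazol-3-yl in place of carbamoyl on a saturated ring carbon. For the measured compounds named here, no measured step exchanges one group of this kind for another on that ring carbon; the only step touching that carbon, a 14-fold lower number from compound 1 to compound 3 (1.15 log units; beyond the scatter), shows that a carbamoyl there is strongly preferred over a hydroxy, and the triazole keeps a hydrogen-bond donor and acceptors as counted. The number for compound 4 is therefore expected to remain near that of compound 3, with a step of a 1.4-fold higher number from compound 3 to compound 4 (0.15 log units; within the scatter) not clearly beyond the scatter. Compound 4 is estimated at 10 nM, between 3 nM and 40 nM.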

Compound 4, half-maximal inhibitory concentration: 34 nM
For compound 4 the middle estimate is 3.4-fold (0.53 log units) below the measured one, within the range that was stated.
By their numbers in this assay, from the lowest: compound 3; then compounds 4, 2 and 1 (each within the scatter of the next, the first and the last beyond it).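

A ring-bearing group is accepted on this saturated ring carbon, but exchanging carbamoyl for 1H-1,2,4-triazol-3-yl costs potency in this assay, with a 4.9-fold higher number from compound 3 to compound 4 (0.69 log units; beyond the scatter), even though the two groups count the same number of hydrogen-bond donors. The matching hydrogen-bond donor count is therefore not enough to hold the number of compound 3. The triazole still improves on hydroxy, with a 2.9-fold lower number from compound 1 to compound 4 (0.47 log units; beyond the scatter), so the gain over hydroxy at this carbon is not confined to carbamoyl, although carbamoyl gives the lowest number of the four compounds.

Open, on these data alone, is where a carboxylic acid, a primary amine or an N-methyl carbamoyl on the same ring carbon would fall relative to compound 3 and compound 4. Nothing available explains the difference between carbamoyl and the triazole.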